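The source may report more compounds than this note shows. Statements on the series, on what has been measured and on what is new or still open speak of the compounds shown alone.

Measured in an ADME assay on HPC cells (Homo sapiens) for cytotoxicity, with a stated time of 24 h (a lower number here means that less compound is tolerated, a higher number that more compound is tolerated), so far:
- Compound 1 `COc1cc(/C=C2\CCC/C(=C\c3cccc([N+](=O)[O-])c3)C2=O)cc(OC)c1OC` gives > 400000 nM as a limit
- Compound 2 `O=C1/C(=C/c2ccccc2)CCC/C1=C\c1ccc([N+](=O)[O-])cc1` gives 123000 nM as a number
- Compound 3 `O=C1/C(=C/c2ccc(F)cc2)CCC/C1=C\c1ccc([N+](=O)[O-])cc1` gives > 400000 nM as a limit

Compound 3 stands at the limit of > 400000 nM in this assay, at which 2 of the 3 values shown sit, and so has no exact number. Compound 4 `O=C1/C(=C/c2ccc(Cl)cc2)CCC/C1=C\c1ccc([N+](=O)[O-])cc1` differs from it by one swap (chloro in place of fluoro on an aromatic carbon), chloro in place of fluoro on an aromatic carbon. For the measured compounds named here, the only measured step that bears on this is an at least 3.2-fold higher number from compound 2 to compound 3 (0.51 log units; beyond the scatter) and it involved fluoro and hydrogen, not chloro, so it offers only loose guidance. A small downward step in this assay is therefore expected, estimated as an at least 1.6-fold lower number from compound 3 to compound 4 (0.20 log units; that floor lies within the scatter) and perhaps no larger than the scatter. For compound 4 the expected value is 250000 nM with an estimated range from 90000 nM to 400000 nM as the likely span.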

Compound 4, half-maximal cytotoxic concentration: 345000 nM
Beside the measured number, compound 4's estimate is 1.4-fold (0.14 log units) below it; the measured number falls inside the stated range.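

In this assay, chloro in place of hydrogen on this aromatic carbon gives a 2.8-fold higher number from compound 2 to compound 4 (0.45 log units; beyond the scatter), so the rise seen with fluoro is not confined to that one halogen. Compound 3 gives > 400000 nM, which is a limit. Chloro in place of fluoro therefore reads only as an at least 1.1-fold lower number from compound 3 to compound 4 (0.06 log units; that floor lies within the scatter), and the true size of that step stays unknown because compound 3 sits at the limit: the limit of > 400000 nM in this assay, at which 2 of the 4 values shown sit.

The compounds shown leave open whether a non-halogen group at this place, such as a methyl group or an amine, would also raise the number over hydrogen.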